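A few compounds are considered here, and "the series" means these few. Any claim that something is new, unique, unknown or untested is made for them only; others in the source may bear on it.

Compound 1, `Cc1ccc(S(=O)(=O)c2nc3ccccc3nc2Nc2ccc(N)cc2)cc1`, and compound 3, `COc1ccc(S(=O)(=O)c2nc3ccccc3nc2Nc2ccc(N)cc2)cc1`, share a core that differs only as methoxy in place of methyl on an aromatic carbon describes, and in a functional assay on PC-3 cells (Homo sapiens) for cytotoxicity, read by MTT assay, with a stated time of 72 h (on this read-out higher numbers stand for weaker inhibition and lower numbers for stronger inhibition), compound 1 gives 5000 nM while compound 3 gives 9640 nM, a gap told by a 1.9-fold higher number from compound 1 to compound 3 (0.29 log units; within the scatter). Compound 2, `Cc1ccc(S(=O)(=O)c2nc3ccccc3nc2Nc2cccc(N)c2)cc1`, carries the change 3-aminophenyl in place of 4-aminophenyl on a nitrogen on an aromatic ring on the core of compound 1, and in this assay compound 2 gives 2000 nM, so that a 2.5-fold lower number from compound 1 to compound 2 (0.40 log units; beyond the scatter). Compound 4, `COc1ccc(S(=O)(=O)c2nc3ccccc3nc2Nc2cccc(N)c2)cc1`, carries the same change, (3-aminophenyl in place of 4-aminophenyl on a nitrogen on an aromatic ring), on the core of compound 3; the surroundings of the place are the same in both pairs, so the two changes are the same change. The step from compound 3 to compound 4 is expected to resemble the measured one, estimated as a 2.4-fold lower number from compound 3 to compound 4 (0.38 log units; beyond the scatter), because compound 2 gives 2000 nM against compound 1. Compound 4 is therefore expected to give about 4000 nM, estimated between 1800 nM and 9000 nM.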

Compound 4, half-maximal inhibitory concentration: 8600 nM
Beside the measured number, compound 4's estimate is 2.2-fold (0.33 log units) below it; the measured number falls inside the stated range.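

In this assay, the change to 3-aminophenyl from 4-aminophenyl on the methoxy core gives a 1.1-fold lower number from compound 3 to compound 4 (0.05 log units; within the scatter), and this step stands beside the one on the methyl core: the same change on two cores in this assay, a 2.5-fold lower number (0.40 log units; beyond the scatter) from compound 1 to compound 2 and a 1.1-fold lower number (0.05 log units; within the scatter) from compound 3 to compound 4, 2.2-fold (0.35 log units) apart, within the scatter of two such steps. The change to methoxy from methyl on the cores carrying 3-aminophenyl gives a 4.3-fold higher number from compound 2 to compound 4 (0.63 log units; beyond the scatter), and this step stands beside the one on the cores carrying 4-aminophenyl: the same change on two cores in this assay, a 1.9-fold higher number (0.29 log units; within the scatter) from compound 1 to compound 3 and a 4.3-fold higher number (0.63 log units; beyond the scatter) from compound 2 to compound 4, 2.2-fold (0.35 log units) apart, within the scatter of two such steps. Each change is thus compatible with carrying over between these cores, but two pairs per change do not show that its size is preserved, and the aminophenyl step lies beyond the scatter on one core and within it on the other.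

The compounds shown leave open whether the same holds with a hydroxyl or a carboxylic acid in place of the amine on the phenyl ring. They also leave open how a chlorine or an ethyl group in place of methyl or methoxy would behave.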